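The source may hold more compounds than are shown below. What is called first, only, known or untested is meant among the compounds shown, and "the series" means these compounds.

Of the compounds shown here, three from this series have been measured in an ADME assay on HepG2 cells (Homo sapiens) for inhibition, read by fluorescence and resazurin assay, with a stated time of 72 h; a lower number here means a stronger inhibitor, a higher number a weaker inhibitor. Compound 1 `Cc1ccc(Nc2nccc(Nc3ccc4cn[nH]c4c3)n2)cc1` gives 18000 nM in this assay. Compound 2 `CN1CCN(c2cccc(Nc3nccc(Nc4ccc5nc[nH]c5c4)n3)c2)CC1` gives 11000 nM, and compound 3 `CN1CCN(c2cccc(Nc3nccc(Nc4ccc5cn[nH]c5c4)n3)c2)CC1` gives 6700 nM. Going by the values given here, the lowest number of the three belongs to compound 3; its nearest neighbour is compound 2, and the single measured step, a 1.6-fold lower number from compound 2 to compound 3 (0.22 log units; within the scatter), is within the scatter, so the two cannot be ordered. Compound 1 stands furthest away, beyond the scatter.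

Compound 4 `Brc1cccc(Nc2nccc(Nc3ccc4cn[nH]c4c3)n2)c1` is the next compound to be measured. It differs from compound 3 in one place: bromo in place of 4-methylpiperazin-1-yl on an aromatic carbon. Among the compounds with values here, none of the measured steps involves this change; the one measured step concerns a different ring and is within the scatter, so it gives no guide to size or direction here. The only other point of reference is compound 1, which carries a small substituent on the same ring and gives 18000 nM, a higher number than compound 3. Compound 4 is therefore expected to give a somewhat higher number than compound 3, the step of a 1.8-fold higher number from compound 3 to compound 4 (0.25 log units; within the scatter) being the estimate, though with wide uncertainty. The estimate for compound 4 in this assay is 12000 nM, with a range from 4500 nM to 32000 nM.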

Compound 4, half-maximal inhibitory concentration: 17000 nM
For compound 4 the middle estimate is 1.4-fold (0.15 log units) below the measured one; the range from low to high includes it.
By their numbers in this assay, from the lowest: compounds 3, 2, 4 and 1 (each within the scatter of the next, the first and the last beyond it).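

In this assay, going by these compounds alone, this aromatic carbon is the first place where a single change gives a step beyond the scatter: bromo in place of 4-methylpiperazin-1-yl gives a 2.5-fold higher number from compound 3 to compound 4 (0.40 log units; beyond the scatter), a modest step, whereas the earlier step on the other ring stayed within the scatter. The second new step, a 1.1-fold lower number from compound 1 to compound 4 (0.02 log units; within the scatter), is within the scatter, so 3-bromophenyl and 4-methylphenyl on that nitrogen cannot be told apart in this assay, and the two compounds cannot be ordered. Nothing available accounts for the step from 4-methylpiperazin-1-yl to bromo.

The compounds shown do not tell whether the lower number of compound 3 goes with the six-membered non-aromatic ring as a whole, with its two nitrogens or with the methyl on it, a question that a morpholine, a piperidine or an open-chain dimethylamino group at the same carbon would bear on. They also leave open whether the same exchange gives a step of similar size with 1H-benzimidazol-6-yl in place of 1H-indazol-6-yl.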